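A few compounds are considered here, and "the series" means these few. Any claim that something is new, unique, unknown or untested is made for them only; others in the source may bear on it.

Measured so far in an ADME assay on microsomes from liver (Homo sapiens) for metabolic stability, tested at 2.5 uM; on this read-out higher numbers stand for fast clearance and lower numbers for slow clearance:
compound 1 `COc1ccc(-c2c(S(=O)(=O)c3ccc(C)c(C)c3)cnc3cc(F)ccc23)cc1` gives 4.13 mL/min
compound 2 `COc1ccc(-c2c(S(=O)(=O)c3ccc(F)c(Cl)c3)cnc3cc(F)ccc23)cc1` gives 1.08 mL/min
compound 3 `Cc1ccc(S(=O)(=O)c2cnc3cc(F)ccc3c2-c2cccc(F)c2)cc1C` gives 3.71 mL/min

Compound 2 differs from compound 1 by 3-chloro-4-fluorophenyl in place of 3,4-dimethylphenyl on a sulfonyl sulfur, and this gave a 3.8-fold lower number from compound 1 to compound 2 (0.58 log units; beyond the scatter). Compound 3 differs from compound 1 by 3-fluorophenyl in place of 4-methoxyphenyl on an aromatic carbon, which gave a 1.1-fold lower number from compound 1 to compound 3 (0.05 log units; within the scatter); the two cores therefore sit close together on this read-out.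

Compound 4 `O=S(=O)(c1ccc(F)c(Cl)c1)c1cnc2cc(F)ccc2c1-c1cccc(F)c1` has not been measured. It differs from compound 3 by 3-chloro-4-fluorophenyl in place of 3,4-dimethylphenyl on a sulfonyl sulfur, the same change as that from compound 1 to compound 2, at the same place. A step of a 3.7-fold lower number from compound 3 to compound 4 (0.57 log units; beyond the scatter) is expected in this assay, resting on the earlier step of a 3.8-fold lower number from compound 1 to compound 2 (0.58 log units; beyond the scatter) applied to the number of compound 3. Compound 4 is thus expected to give about 1 mL/min, with a likely range from 0.5 mL/min to 2.2 mL/min.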

Compound 4, intrinsic clearance in a liver preparation (reported as CLH), per the amount of preparation that the assay uses: 0.25 mL/min
Beside the measured number, compound 4's estimate is 4.0-fold (0.60 log units) above it; the whole stated range lies above it.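

In this assay, 3-chloro-4-fluorophenyl in place of 3,4-dimethylphenyl on a sulfonyl sulfur lowers the number on both cores, but its size does not carry over, with a 15-fold lower number from compound 3 to compound 4 (1.17 log units; beyond the scatter) on the second core: the same change on two cores in this assay, a 3.8-fold lower number (0.58 log units; beyond the scatter) from compound 1 to compound 2 and a 15-fold lower number (1.17 log units; beyond the scatter) from compound 3 to compound 4, 3.9-fold (0.59 log units) apart, beyond the scatter of two such steps. Read the other way round, 3-fluorophenyl in place of 4-methoxyphenyl on an aromatic carbon gives a 4.3-fold lower number from compound 2 to compound 4 (0.64 log units; beyond the scatter), so the two changes do not add independently: the same change on two cores in this assay, a 1.1-fold lower number (0.05 log units; within the scatter) from compound 1 to compound 3 and a 4.3-fold lower number (0.64 log units; beyond the scatter) from compound 2 to compound 4, 3.9-fold (0.59 log units) apart, beyond the scatter of two such steps. These four compounds show that the direction of the sulfonyl change held on two cores, but they do not show its size on a further core or why the steps differ.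

Still open, as far as these compounds go, is whether that direction holds with an amine or a longer chain in place of 3-fluorophenyl on an aromatic carbon. Also open, from the compounds shown here alone, is how a phenyl carrying a carboxylic acid on the sulfonyl sulfur would behave.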